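Replacing 2,4-dimethoxyphenyl with 2,3,4-trifluorophenyl

A few compounds are considered here, and "the series" means these few. Any claim that something is new, unique, unknown or untested is made for them only; others in the source may bear on it.

- Compound 1 (`OC[C@H]1O[C@@H](n2cnc3c(NCc4ccc(F)cc4)ncnc32)[C@H](O)[C@@H]1O`) gives 2700 nM
- Compound 2 (`COc1ccc(CNc2ncnc3c2ncn3[C@@H]2O[C@H](CO)[C@@H](O)[C@H]2O)c(OC)c1`) gives > 166000 nM as a limit
- Compound 3 (`OC[C@H]1O[C@@H](n2cnc3c(NCc4ccc(F)c(F)c4F)ncnc32)[C@H](O)[C@@H]1O`) has not yet been measured

These values come from a functional assay on K562 cells (Homo sapiens) for antiproliferative activity, with a stated time of 72 h (on this read-out lower numbers stand for stronger inhibition and higher numbers for weaker inhibition), alone. Compound 2 gives only a limit (the limit of > 166000 nM in this assay, at which 1 of the 2 values shown sits) and no exact number. Going to compound 3, 2,3,4-trifluorophenyl replaces 2,4-dimethoxyphenyl (2,3,4-trifluorophenyl in place of 2,4-dimethoxyphenyl on a saturated chain carbon bound to a nitrogen on an aromatic ring) on a saturated chain carbon bound to a nitrogen on an aromatic ring.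

Among the compounds with values here, one measured step bears on this exchange. When 2,4-dimethoxyphenyl came in place of 4-fluorophenyl, the result was an at least 61-fold higher number from compound 1 to compound 2 (1.78 log units; beyond the scatter) and this large step lies beyond the scatter. Compound 3 gives up the same 2,4-dimethoxyphenyl for a fluorinated group, so a large step towards lower numbers is expected in this assay and a value in the region of compound 1 at 2700 nM seems likely. Within the data shown here, no measured step separates 2,3,4-trifluorophenyl from 4-fluorophenyl, so the range stays wide. The estimated step is an at least 41-fold lower number from compound 2 to compound 3 (1.61 log units; beyond the scatter) in this read-out. For compound 3 the estimate is 4000 nM with an expected range of 1000 nM to 20000 nM in this assay here.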

Compound 3, half-maximal inhibitory concentration: > 166000 nM
Compound 3: only a limit was reported (the forecaster's own chance of this, stated with the estimate: 10%); middle value at least 41-fold (1.61 log units) away from the limit.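

In this assay, a fluorinated group at this place does not by itself preserve the measurable activity of compound 1: 2,3,4-trifluorophenyl in place of 4-fluorophenyl gives an at least 61-fold higher number from compound 1 to compound 3 (1.78 log units; beyond the scatter). The loss seen earlier is therefore not tied to 2,4-dimethoxyphenyl alone, and of the three compounds only compound 1, with its 4-fluorophenyl group, has an exact value. Compound 3, like compound 2, is reported only as a limit, so the step between these two cannot be read: the limit of > 166000 nM in this assay, at which 2 of the 3 values shown sit.

The compounds shown leave open how far compound 2 and compound 3 lie from that limit, and therefore whether these two groups differ at all on this read-out. They also leave open whether the exact value of compound 1 depends on having a single fluorine on the phenyl ring, and how a plain phenyl or a 4-chlorophenyl group would behave on the same saturated chain carbon bound to a nitrogen on an aromatic ring.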